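Swapping the Group Between the Two Ring Nitrogens

A few compounds are considered here, and "the series" means these few. Any claim that something is new, unique, unknown or untested is made for them only; others in the source may bear on it.

Of the compounds shown here, three from one series have been measured in an assay on membranes from HEK293 cells for displacement of a labelled ligand from Type-2 angiotensin II receptor (Homo sapiens), read by radioligand binding; a higher number here means a weaker inhibitor, a lower number a stronger inhibitor. Compound 1 `CCCc1ccc(S(=O)(=O)NC(=O)OCCC(F)(F)C(F)(F)F)c(-c2ccc(Cn3c(C(C)(C)C)nc4ccccc43)cc2)c1` gives 6 nM. Compound 2 `CCCCOC(=O)NS(=O)(=O)c1ccc(CCC)cc1-c1ccc(Cn2c(-c3nccs3)nc3ccccc32)cc1` gives 5.1 nM. Compound 3 `CCCCOC(=O)NS(=O)(=O)c1ccc(CCC)cc1-c1cc(F)c(Cn2c(C(C)(C)C)nc3ccccc32)c(F)c1` gives 11 nM. Within the data shown here, of these three numbers, the one for compound 2 is the lowest, but compound 1 lies within the scatter of it, so the two cannot be separated; only compound 3 sits beyond the scatter, with the higher number. Compound 1 and compound 2 differ in more than one place, so their values show only that both are near each other.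

The next compound, compound 4 `CCCCOC(=O)NS(=O)(=O)c1ccc(CCC)cc1-c1ccc(Cn2c(CCCC)nc3ccccc32)cc1`, is derived from compound 2 by a single change: butyl in place of 1,3-thiazol-2-yl on an aromatic carbon. Among the measured compounds shown here, no measured pair in this set isolates this kind of change, so there is no step to lean on. Compound 1 carries a tert-butyl at the same position, together with a different carbamate chain, and its value of 6 nM is close to that of compound 2, which suggests this position tolerates a non-aromatic group.

The step from compound 2 to compound 4 is therefore expected to be small, a 1.6-fold higher number from compound 2 to compound 4 (0.20 log units; within the scatter), and not beyond the scatter. Compound 4 is estimated at 8 nM, within a range of 3 nM to 25 nM in this assay.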

Compound 4, inhibition constant: 9.2 nM
Compound 4: the middle estimate sits 1.2-fold (0.06 log units) below what was measured; measured number inside the range.
By their numbers in this assay, from the lowest: compounds 2, 1, 4 and 3 (each within the scatter of the next, the first and the last beyond it).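

Among these compounds, the step of a 1.8-fold higher number from compound 2 to compound 4 (0.26 log units; within the scatter) in this assay is the first comparison in this set that changes only the group on the aromatic carbon between two ring nitrogen atoms. It replaces 1,3-thiazol-2-yl, a five-membered aromatic ring with two hetero atoms and two hydrogen-bond acceptors, with butyl, an open carbon chain with no ring and no hydrogen-bond acceptors, and the two numbers cannot be told apart. At this position, with the rest of the structure held constant, neither the ring nor its acceptors is needed for a value in this range, although no measurement here explains why the two groups read alike.

Among the compounds shown here, what remains open is how far this tolerance extends, since one pair spans only two groups at this carbon: a much longer chain such as octyl, a carboxylic acid, or an amine could behave differently. It is also unclear whether butyl and 1,3-thiazol-2-yl would still read alike if the carbamate chain or the rest of the shared core were changed.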